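Chloro substitution on the pyridine amide: an expected small step

The source may report more compounds than this note shows. Statements on the series, on what has been measured and on what is new or still open speak of the compounds shown alone.

Compound 1 `C=C(C)COc1ccc(C(=O)Nc2cccc(C)n2)cc1`: 19600 nM
Compound 2 `CCOc1ccc(C(=O)Nc2cc(C)cc(C)n2)cc1`: 17100 nM
Compound 3 `C=CCOc1ccc(C(=O)Nc2ccccn2)cc1`: 19300 nM

Three amides sharing one core have been measured in an in vitro assay on HEK-tsA201 cells for antagonist activity at Neuronal acetylcholine receptor; alpha4/beta2 (Homo sapiens), read by fluorescence and calcium flux; a higher number here means a weaker inhibitor, a lower number a stronger inhibitor. Compound 1 gives 19600 nM, compound 2 gives 17100 nM, and compound 3 gives 19300 nM. In this assay compound 3 has the second highest of the three numbers; its nearest neighbour is compound 1, which lies within the scatter, and the furthest is compound 2, which also lies within the scatter. The three numbers are therefore indistinguishable on this evidence.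

Compound 4 `C=CCOc1ccc(C(=O)Nc2cccc(Cl)n2)cc1` has not been measured. It differs from compound 3 in one place: chloro in place of hydrogen on an aromatic carbon, on an aromatic carbon of a six-membered aromatic ring with one nitrogen, next to the ring nitrogen and meta to a large group. Among the measured compounds shown here, no step between measured compounds shows what such a chloro for hydrogen exchange does in this assay, so no direction can be taken from the data. The author expects the step from compound 3 to compound 4 to be small, a 1.1-fold lower number from compound 3 to compound 4 (0.03 log units; within the scatter), and not beyond the scatter. Compound 4 is estimated at 18000 nM, with a range from 7000 nM to 45000 nM.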

Compound 4, half-maximal inhibitory concentration: > 100000 nM
Compound 4: no number, only a limit (the forecaster's own chance of this, stated with the estimate: 25%); middle value at least 5.5-fold (0.74 log units) from the limit.
By their numbers in this assay, from the lowest: compounds 2, 3 and 1 (each within the scatter of the next). At a limit, above all of these: compound 4.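

In this assay, the aromatic carbon next to the ring nitrogen and meta to a large group proves sensitive to substitution: chloro in place of hydrogen gives an at least 5.1-fold higher number from compound 3 to compound 4 (0.71 log units; beyond the scatter). Among the compounds shown here, this is the first single-place step available, and it shows that one chlorine at this position can carry the number beyond the scatter. The value of compound 4 is a limit and not a number, and the full size of the step remains unknown: the limit of > 100000 nM in this assay, at which 1 of the 4 values shown sits.

The compounds shown leave open whether fluoro, methoxy or an amine at this position would have a similar effect, and whether chloro on another carbon of the ring would do the same. Compound 1 also bears a methyl group at this position, but it differs from compound 3 in more than one place, and the effect of that methyl group cannot be read.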